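Series notes: thiazole acetic acids, aryl replacement at the core

The source may hold more compounds than are shown below. What is called first, only, known or untested is meant among the compounds shown, and "the series" means these compounds.

Measured so far:
compound 1 `O=C(O)Cc1sc(C(c2ccc(F)cc2)c2ccc(F)cc2)nc1-c1ccoc1`, in an in vitro assay on HEK385-7 cells for displacement of a labelled ligand from prostaglandin D2 receptor 2 (Homo sapiens) (on this read-out higher numbers stand for weaker inhibition and lower numbers for stronger inhibition), compound 1 gives 14 nM
compound 2 `O=C(O)Cc1sc(C(c2ccc(F)cc2)c2ccc(F)cc2)nc1-c1ccnc(F)c1`, in this assay compound 2 gives 0.48 nM

Going by the values given here, compound 2 has the lowest number of the two; its only neighbour is compound 1, and the step of a 29-fold lower number from compound 1 to compound 2 (1.46 log units; beyond the scatter) lies beyond the scatter. Among the compounds with values here, that step is the single piece of evidence on the aryl group attached to the shared core.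

The unmeasured compound 3 `Cc1cc(-c2nc(C(c3ccc(F)cc3)c3ccc(F)cc3)sc2CC(=O)O)cnc1N` differs from compound 2 at the same aromatic carbon: 6-amino-5-methylpyridin-3-yl in place of 2-fluoropyridin-4-yl on an aromatic carbon. The group that enters sits at the same position as the 2-fluoropyridin-4-yl group of compound 2, so the step of a 29-fold lower number from compound 1 to compound 2 (1.46 log units; beyond the scatter) is the one that bears on it, and it is large. It does, however, concern a furan-3-yl group rather than a second pyridyl, so it gives no direction for an exchange of one six-membered aromatic ring with 1 hetero atom for another. With one six-membered aromatic ring kept, a step in this assay of modest size at most is expected, if anything toward a higher number.

For compound 3 the expected step is a 3.1-fold higher number from compound 2 to compound 3 (0.49 log units; beyond the scatter).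

Compound 3 is estimated at 1.5 nM in this assay, in the range 0.4 nM to 6 nM.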

Compound 3, half-maximal inhibitory concentration: 880 nM
Compound 3: the middle estimate sits 590-fold (2.77 log units) below what was measured; measured number above the stated range.
By their numbers in this assay, from the lowest: compound 2; then compound 1; then compound 3.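

In this assay, the exchange of one six-membered aromatic ring with 1 hetero atom for another proves far from neutral at this position: the change gives a 1800-fold higher number from compound 2 to compound 3 (3.26 log units; beyond the scatter), so the aromatic carbon next to the ring nitrogen distinguishes sharply between two pyridyl groups. The 6-amino-5-methylpyridin-3-yl group also gives a higher number than the furan-3-yl group, with a 63-fold higher number from compound 1 to compound 3 (1.80 log units; beyond the scatter), so the gain seen earlier with 2-fluoropyridin-4-yl does not extend to every pyridyl group placed here. Nothing on hand accounts for the size of this loss.

The step changes several features at once: the fluorine leaves, an amine and a methyl enter, and the pyridine ring is joined through a different ring carbon, and the compounds shown do not separate these changes. On these data alone, it remains open whether a pyridin-3-yl group carrying only the amine, only the methyl or only a fluorine would give a number close to that of compound 2 or close to that of compound 3.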